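The source may report more compounds than this note shows. Statements on the series, on what has been measured and on what is new or still open speak of the compounds shown alone.

In an in vivo ADME assay on the whole organism for pharmacokinetics, with Canis familiaris (Canis lupus familiaris) as the target (a lower number here means slower removal, a higher number faster removal of the compound), compound 3 (`CNCc1ccccc1-c1ccc(N2CCc3c(C(F)(F)F)nn(-c4ccc5onc(N)c5c4)c3C2=O)cc1`) gives 27.7 mL/min/kg, compound 1 (`Nc1noc2ccc(-n3nc(C(F)(F)F)c4c3C(=O)N(c3ccc(-c5ccccc5CN5CCCC5)cc3)CC4)cc12`) gives 16.8 mL/min/kg and compound 2 (`Nc1noc2ccc(-n3nc(C(F)(F)F)c4c3C(=O)N(c3ccc(-c5ccccc5CN5CCC(O)CC5)cc3)CC4)cc12`) gives 3.5 mL/min/kg. Compound 3 thus sits within the scatter of compound 1, with a 1.6-fold higher number from compound 1 to compound 3 (0.22 log units; within the scatter), and clearly apart from compound 2, with a 7.9-fold higher number from compound 2 to compound 3 (0.90 log units; beyond the scatter).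

Compound 4 (`CN(C)Cc1ccccc1-c1ccc(N2CCc3c(C(F)(F)F)nn(-c4ccc5onc(N)c5c4)c3C2=O)cc1`) differs from compound 3 by a single change: methyl in place of hydrogen on an amine nitrogen. Among the compounds with values here, no measured step makes exactly this change, so the evidence is indirect. Compound 4, like compound 1, keeps no hydrogen on the amine nitrogen, and the measured step of a 1.6-fold higher number from compound 1 to compound 3 (0.22 log units; within the scatter) stayed within the scatter. Within the data shown here, the larger step of a 4.8-fold lower number from compound 1 to compound 2 (0.68 log units; beyond the scatter) brings in the 4-hydroxypiperidin-1-yl group, which has no counterpart in compound 4, so it bears little on this change. No step beyond the scatter is therefore expected in this assay, with at most a small drift towards a lower number. The expected change is a 1.3-fold lower number from compound 3 to compound 4 (0.12 log units; within the scatter), which would remain within the scatter. For compound 4 the estimate is 21 mL/min/kg, with an expected range of 11 mL/min/kg to 38 mL/min/kg.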

Compound 4, clearance: 16.3 mL/min/kg
Estimate against measurement, compound 4: 1.3-fold (0.11 log units) above; measured number inside the range.
By their numbers in this assay, from the lowest: compound 2; then compounds 4, 1 and 3 (each within the scatter of the next).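

In this assay, within the data shown here, methyl in place of hydrogen on the amine nitrogen gives a 1.7-fold lower number from compound 3 to compound 4 (0.23 log units; within the scatter), so the first direct reading of methylamino to dimethylamino at this position stays within the scatter. Dimethylamino and pyrrolidin-1-yl on the saturated chain carbon cannot be told apart here, with a 1.0-fold lower number from compound 1 to compound 4 (0.01 log units; within the scatter), and the fully substituted amines with no ring and with a ring thus read alike in this pair. Compound 2 alone stands clear of the other three, as a 4.7-fold higher number from compound 2 to compound 4 (0.67 log units; beyond the scatter) confirms for the new compound, and no measurement in hand accounts for either the small steps or this larger one.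

From the compounds shown here alone, the 4-hydroxypiperidin-1-yl step changes both the amine ring and the hydroxyl at once, so the share of each stays open until piperidin-1-yl or morpholin-4-yl can be set against compound 2. Also open, going by these compounds, is how the primary aminomethyl group, or a longer chain between the aromatic carbon and the amine nitrogen, would read.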